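The compounds below may be only part of what the source reports. "The series", "measured", "known", "first", "only" and "open" are said of these compounds alone.

Compound 3 `COCCOc1ccc(-c2sc(N)c(C(=O)c3ccc(Cl)cc3)c2CC(C)(C)C)cc1` belongs to a small set of related compounds sharing one core. Its two companions are compound 1 `CC(C)(C)Cc1c(/C=C/c2ccc(Cl)cc2)sc(N)c1C(=O)c1ccc(Cl)cc1` and compound 2 `CC(C)(C)Cc1c(-c2ccc(Cl)c(Cl)c2)sc(N)c1C(=O)c1ccc(Cl)cc1`. In an assay on CHO cells for displacement of a labelled ligand from adenosine receptor A1 (Homo sapiens), read by scintillation counting, tested at 10 uM (on this read-out lower numbers stand for less inhibition and higher numbers for more inhibition at the one concentration tested (going by the name of the read-out)), compound 1 gives 1%, compound 2 gives 1% and compound 3 gives 1%. Among the compounds with values here, the one step measured within this set, no change at the digits printed from compound 1 to compound 2 (within the scatter), shows that exchanging one group for another on an aromatic carbon left the read-out flat. On these numbers compound 3 stands level with both of its companions; nothing separates it from either.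

Compound 4 `CC(C)c1ccc(-c2sc(N)c(C(=O)c3ccc(Cl)cc3)c2CC(C)(C)C)cc1` has not yet been measured in this assay. It differs from compound 3 in one place: isopropyl in place of 2-methoxyethoxy on an aromatic carbon. Within the data shown here, no measured step covers this exact exchange; the closest thing the set offers is no change at the digits printed from compound 1 to compound 2 (within the scatter), which swapped one substituent for another on an aromatic carbon without moving the read-out. All three measured compounds sit at the same low level, and the exchange of the 2-methoxyethoxy for the isopropyl is of a similar kind, a swap of one substituent for another on an aromatic carbon. The step from compound 3 to compound 4 is therefore expected to be a number 1 percentage points higher from compound 3 to compound 4 (within the scatter), none beyond the scatter. Compound 4 is estimated at 2%, between -8% and 12%.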

Compound 4, a percentage reported as inhibition, at one concentration (the size of the read-out at that concentration, not a potency): 1%
For compound 4 the middle estimate is 1 percentage points above the measured one; measured number inside the range.
By their numbers in this assay, from the lowest: compounds 1, 2, 3 and 4 (each within the scatter of the next).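

At the aromatic carbon para to a large group, the earlier compounds had shown no exchange of this kind: replacing the oxygen-bearing 2-methoxyethoxy with the all-carbon isopropyl gives no change at the digits printed from compound 3 to compound 4 (within the scatter) in this assay, so removing both ether oxygens and shortening the substituent leaves this read-out flat. The larger exchanges of the whole aromatic substituent read the same way, with no change at the digits printed from compound 2 to compound 4 (within the scatter) and no change at the digits printed from compound 1 to compound 4 (within the scatter), which places 4-isopropylphenyl alongside 3,4-dichlorophenyl and 2-(4-chlorophenyl)ethenyl in this set. There is no evidence here that could explain this flat picture.

All four compounds sit at the same low level, so the set cannot show whether this position matters at all for this assay or whether the shared core simply gives little inhibition whatever stands there. Going by these compounds, it remains open whether an amine, a carboxylic acid or a longer chain ending in a hydroxyl on this same aromatic carbon would move the read-out beyond the scatter, and whether changes elsewhere on the shared core would do so.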